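Amide substituent step from compound 3 to compound 4

A few compounds are considered here, and "the series" means these few. Any claim that something is new, unique, unknown or untested is made for them only; others in the source may bear on it.

Measured in an ADME assay on HEp-2 cells (Homo sapiens) for cytotoxicity; a lower number here means that less compound is tolerated, a higher number that more compound is tolerated:
- compound 1 `O=C(Nc1ccccc1)[C@@H]1CCCN1S(=O)(=O)c1cccc2cccnc12`: 35600 nM
- compound 2 `Cc1cccc(C)c1NC(=O)[C@@H]1CCCN1S(=O)(=O)c1cccc2cccnc12`: > 50000 nM (a limit)
- compound 3 `Cc1ccc(Cl)c(NC(=O)[C@@H]2CCCN2S(=O)(=O)c2cccc3cccnc23)c1`: > 50000 nM (a limit)

Compound 3 has no exact number and stands at the limit of > 50000 nM in this assay, at which 2 of the 3 values shown sit. The next compound, compound 4 `Cc1cc(NC(=O)[C@@H]2CCCN2S(=O)(=O)c2cccc3cccnc23)n(C(C)(C)C)n1`, changes the group on the amide-type nitrogen: 3-methyl-1-(tert-butyl)-1H-pyrazol-5-yl in place of 2-chloro-5-methylphenyl on an amide-type nitrogen.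

Going by the values given here, two measured steps bear on this place: an at least 1.4-fold higher number from compound 1 to compound 2 (0.14 log units; that floor lies within the scatter) and an at least 1.4-fold higher number from compound 1 to compound 3 (0.14 log units; that floor lies within the scatter). Neither shows a change beyond the scatter. The remaining comparison is a step that the two limits leave unreadable from compound 2 to compound 3. Among the compounds with values here, no measured compound carries a five-membered aromatic ring, so these steps offer only loose guidance for the new group. With only these small floors to go on, no step beyond the scatter and no particular direction is expected in this assay. The estimated step is an at least 1.1-fold lower number from compound 3 to compound 4 (0.04 log units; that floor lies within the scatter). For compound 4 the expected value is 45000 nM, with an estimated range from 20000 nM to 70000 nM.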

Compound 4, half-maximal cytotoxic concentration: > 50000 nM
Compound 4 was reported as a limit; the forecaster's own chance of this, stated with the estimate: 55%; middle value at least 1.1-fold (0.04 log units) away from the limit.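

In this assay compound 4 gives > 50000 nM, which is a limit. The change to a five-membered aromatic ring with 2 hetero atoms therefore places 3-methyl-1-(tert-butyl)-1H-pyrazol-5-yl at the same reported limit as 2,6-dimethylphenyl and 2-chloro-5-methylphenyl, so this position now holds six-membered and five-membered aromatic rings at one limit: the limit of > 50000 nM in this assay, at which 3 of the 4 values shown sit. Against phenyl, the only readable step is an at least 1.4-fold higher number from compound 1 to compound 4 (0.14 log units; that floor lies within the scatter), while the steps among the three compounds reported as limits cannot be read.

On these data alone, the order of compound 2, compound 3 and compound 4 in this assay stays open, as does the size of any difference among them. Also open, as far as these compounds go, is whether a group of another kind on the amide-type nitrogen, such as a carboxylic acid or a piperidine ring, would give a step beyond the scatter.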